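The source may hold more compounds than are shown below. What is called first, only, known or untested is meant among the compounds shown, and "the series" means these compounds.

Measured compounds:
compound 1 `NC(=O)[C@@H](CCC(F)(F)F)N(C[C@H]1CCCCO1)S(=O)(=O)c1ccc(Cl)cc1` — > 300 mL/min/kg
compound 2 `NC(=O)[C@@H](CCC(F)(F)F)N(C[C@@H]1CCCCO1)S(=O)(=O)c1ccc(Cl)cc1` — > 300 mL/min/kg

In an in vitro ADME assay on microsomes from liver (Homo sapiens) for metabolic stability, read by HPLC (on this read-out lower numbers stand for slow clearance and higher numbers for fast clearance), compound 1 gives > 300 mL/min/kg, which is a limit of the assay and not a number. Compound 2 gives > 300 mL/min/kg, also a limit. The step that the two limits leave unreadable from compound 1 to compound 2 cannot be read, since both values sit at the limit (the limit of > 300 mL/min/kg in this assay, at which 2 of the 2 values shown sit), and the pair differs only in configuration as drawn (the fact that compounds 1 and 2 differ only in the configuration as drawn). Compound 1 therefore stands at the fast-clearance end of what this assay reports, with no number to place it more exactly.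

Compound 3 `NC(=O)[C@@H](CCC(F)(F)F)N(C[C@@H]1CCCO1)S(=O)(=O)c1ccc(Cl)cc1` has not yet been measured. Relative to compound 1 the change is oxolan-2-yl in place of oxan-2-yl on a saturated chain carbon bound to a sulfonamide nitrogen. Within the data shown here, no measured step bears on this change; the only step in hand is unreadable. With compound 1 at the limit, no shift beyond the scatter in either direction is expected, and the step that the limit leaves unreadable from compound 1 to compound 3 is estimated to stay small. Compound 3 is expected to give about 350 mL/min/kg, estimated between 150 mL/min/kg and 800 mL/min/kg, most likely reported again as a limit.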

Compound 3, clearance: 210 mL/min/kg
For compound 3 the middle estimate is 1.7-fold (0.22 log units) above the measured one; low and high end bracket the measured number.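

In this assay, among these compounds, compound 3 gives 210 mL/min/kg, the first reading at this position that is a number and not a limit, so on a saturated chain carbon bound to a sulfonamide nitrogen, oxolan-2-yl gives a number where oxan-2-yl, in both drawn configurations, gave none. The change reads as an at least 1.4-fold lower number from compound 1 to compound 3 (0.15 log units; that floor lies within the scatter) and as an at least 1.4-fold lower number from compound 2 to compound 3 (0.15 log units; that floor lies within the scatter); both are floors, so the real size may be larger, but no shift beyond the scatter is established. The reference values remain limits: the limit of > 300 mL/min/kg in this assay, at which 2 of the 3 values shown sit.

From the compounds shown here alone, the step between compound 1 and compound 2 cannot be read, and the true size of the ring change remains open. Also open, going by these compounds, is how oxetan-2-yl or an open 2-methoxyethyl chain would read at this position in this assay.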